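Swapping Chloro for Amino on a Shared Core

This account rests on a few compounds, and the source may have more. Where it says the series, first, only, none or still open, it means among the compounds named here.

Compound 2 `Nc1nn(C(=O)Nc2ccc(Cc3ccccc3)cc2)c2ccc(Cl)cc12` gives 53200 nM in a functional assay on LOX IMVI cells (Homo sapiens) for antiproliferative activity, read by sulforhodamine B assay, with a stated time of 48 h (on this read-out higher numbers stand for lower toxicity in this test and lower numbers for higher toxicity in this test), standing alongside compound 1 `Nc1nn(C(=O)Nc2ccc(Cc3ccccc3)cc2)c2ccccc12`, which gives 61500 nM; the two numbers differ only within the scatter. Among the compounds with values here, the single step measured so far, a 1.2-fold lower number from compound 1 to compound 2 (0.06 log units; within the scatter), is too small to reveal any trend. Compound 3 `Nc1ccc2c(c1)c(N)nn2C(=O)Nc1ccc(Cc2ccccc2)cc1` differs from compound 2 by amino in place of chloro on an aromatic carbon. Within the data shown here, no measured step bears on this exchange, so the expected step is a 1.0-fold higher number from compound 2 to compound 3 (0.01 log units; within the scatter), nothing beyond the scatter. Compound 3 is therefore estimated at 55000 nM, with a range from 18000 nM to 160000 nM.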

Compound 3, concentration lethal to 50% of the cells: 46700 nM
The estimate for compound 3 lay 1.2-fold (0.07 log units) above the measured number; the measured number falls inside the stated range.
By their numbers in this assay, from the lowest: compounds 3, 2 and 1 (each within the scatter of the next).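

In this assay, amino in place of chloro on this aromatic carbon gives a 1.1-fold lower number from compound 2 to compound 3 (0.06 log units; within the scatter) and amino in place of hydrogen gives a 1.3-fold lower number from compound 1 to compound 3 (0.12 log units; within the scatter) in the same test. Hydrogen, chloro and amino therefore cannot be told apart at this position, even though amino carries a hydrogen-bond donor and acceptor and chloro carries neither. No measurement is available that would explain this result. Going by these compounds, whether a carboxylic acid or a longer chain at this position would shift the number beyond the scatter remains open.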